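The source may report more compounds than this note shows. Statements on the series, on what has been measured and on what is new or still open speak of the compounds shown alone.

Three compounds sharing one core were tested in a functional assay on aorta (Rattus norvegicus, strain Wistar) for inhibition, with a stated time of 60 min; on this read-out higher numbers stand for larger maximal responses and lower numbers for smaller maximal responses. Compound 1 `Oc1ccc(-c2nc3cc(C(F)(F)F)ccc3[nH]2)cc1` carries a trifluoromethyl on its core, and in this assay compound 1 gives 37%. Compound 2 `COc1ccc(-c2nc3cc([N+](=O)[O-])ccc3[nH]2)c(OC)c1OC` and compound 3 `COc1cc(-c2nc3cc([N+](=O)[O-])ccc3[nH]2)ccc1O` carry a nitro at that place instead; in this assay compound 2 gives 58.9%, and compound 3 gives 55.2%. Among the three, compound 3 stands second highest. Its gap to compound 2 lies within the usual scatter, so these two cannot be ranked against each other, while its gap to compound 1 lies beyond the scatter, so compound 3 reaches a larger maximal response than compound 1.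

Compound 4 `COc1cc(-c2nc3cc(C(F)(F)F)ccc3[nH]2)ccc1O` keeps the substituted phenol of compound 3 and changes one group on the core: trifluoromethyl in place of nitro on an aromatic carbon. Going by the values given here, no pair of measured compounds differs only in this group, so no measured step exists for it. Among the compounds with values here, the only compound carrying a trifluoromethyl, compound 1, sits lowest of the three. A downward step of about a number 13.2 percentage points lower from compound 3 to compound 4 (beyond the scatter) from compound 3 to compound 4 is therefore expected. Compound 4 is estimated to give 42%, with a range from 30% to 55%.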

Compound 4, largest response reached (Emax), in percent of the reference or control that the assay uses: 97.7%
Compound 4: middle estimate off by 55.7 percentage points, on the low side; the measured number lies above the stated range.
By their numbers in this assay, from the lowest: compound 1; then compounds 3 and 2 (each within the scatter of the next); then compound 4.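

In this assay, trifluoromethyl in place of nitro on an aromatic carbon of the shared core gives a number 42.5 percentage points higher from compound 3 to compound 4 (beyond the scatter), so this position responds strongly to the change, and trifluoromethyl there does not by itself go with a low maximal response. Methoxy in place of hydrogen on an aromatic carbon gives a number 60.7 percentage points higher from compound 1 to compound 4 (beyond the scatter), so with trifluoromethyl on the core, the number also depends heavily on this second change elsewhere in the molecule. Nothing given here explains why either step is so large.

The compounds shown leave open whether methoxy would bring a similar rise with nitro on the core. They also leave open how this core position would respond to another group, such as an amine or a carboxylic acid.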